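Methyl on the Amine and Tolerance of Two Cores

The source may report more compounds than this note shows. Statements on the series, on what has been measured and on what is new or still open speak of the compounds shown alone.

Compound 1 `CNc1ccc2nc(-c3c(Cl)nc(N)nc3N[C@@H]3C[C@H](CO)[C@@H](O)[C@H]3O)sc2c1` and compound 2 `CNc1ccc2sc(-c3c(Cl)nc(N)nc3N[C@@H]3C[C@H](CO)[C@@H](O)[C@H]3O)nc2c1` contain the same atoms joined differently; the difference between the two cores is not broken down here. In an ADME assay on cells (Homo sapiens) for cytotoxicity, read by polymerase chain reaction, with a stated time of 3 days (a lower number here means that less compound is tolerated, a higher number that more compound is tolerated), compound 1 gives 6000 nM. In this assay compound 2 gives 20000 nM. Compound 3 `CN(C)c1ccc2nc(-c3c(Cl)nc(N)nc3N[C@@H]3C[C@H](CO)[C@@H](O)[C@H]3O)sc2c1` differs from compound 1 by methyl in place of hydrogen on a nitrogen on an aromatic ring. For compound 3 the value in this assay is a limit of the assay, > 25000 nM. That step, an at least 4.1-fold higher number from compound 1 to compound 3 (0.61 log units; beyond the scatter), runs into (the limit of > 25000 nM in this assay, at which 1 of the 3 values shown sits). Compound 4 `CN(C)c1ccc2sc(-c3c(Cl)nc(N)nc3N[C@@H]3C[C@H](CO)[C@@H](O)[C@H]3O)nc2c1` carries the same change on the core of compound 2, namely (methyl in place of hydrogen on a nitrogen on an aromatic ring). A step like an at least 4.1-fold higher number from compound 1 to compound 3 (0.61 log units; beyond the scatter) is expected again, giving an estimated 3.5-fold higher number from compound 2 to compound 4 (0.54 log units; beyond the scatter). Compound 4 is therefore expected to give about 70000 nM, somewhere between 25000 nM and 200000 nM, very likely reported only as a limit of this assay.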

Compound 4, half-maximal cytotoxic concentration: 25000 nM
The estimate for compound 4 lay 2.8-fold (0.45 log units) above the measured number; the range from low to high includes it.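

In this assay, the methylamino to dimethylamino change on the core of compound 2 gives a 1.3-fold higher number from compound 2 to compound 4 (0.10 log units; within the scatter). The change therefore does not carry over from one core to the other with the same size: the same change on two cores in this assay, an at least 4.1-fold higher number (0.61 log units; beyond the scatter) from compound 1 to compound 3 and a 1.3-fold higher number (0.10 log units; within the scatter) from compound 2 to compound 4, at least 3.3-fold (0.52 log units) apart, beyond the scatter of two such steps. Going by these compounds, compound 3 gives > 25000 nM, which is a limit of the assay, so the full size of its step stays unknown, and two cores cannot establish a rule for the wider series.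

The compounds shown leave open how a longer chain, such as ethyl in place of methyl on a nitrogen on an aromatic ring, would behave on either core in this assay. On these data alone, a morpholine in place of dimethylamino also remains open.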